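Shortening a Saturated Chain in a Small Series

The compounds below may be only part of what the source reports. "The series", "measured", "known", "first", "only" and "open" are said of these compounds alone.

Of the compounds shown here, three that share one core have been measured so far in a functional assay on Cortical neurone cells (Mus musculus, strain C57BL/6), read by FLIPR and calcium flux, with a stated time of 8 min (a higher number here means a weaker inhibitor, a lower number a stronger inhibitor), and they are compound 1 `O=c1cc(Cc2ccccc2)[nH]c2nc(Cc3ccc(Cl)cc3)nn12` at 4280 nM and compound 2 `CCCCCCc1nc2[nH]c(-c3ccc(Cl)cc3)cc(=O)n2n1` at 8720 nM and compound 3 `O=c1cc(-c2ccc(Cl)cc2)[nH]c2nc(-c3ccccc3)nn12` at 2350 nM in the same read-out. Compound 2 holds the highest of these numbers, with compound 1 nearest to it and compound 3 furthest away. Compound 4 `CCCCCc1nc2[nH]c(-c3ccc(Cl)cc3)cc(=O)n2n1` differs from compound 2 by a single edit (hydrogen in place of methyl on a saturated chain carbon, five bonds along the chain from an aromatic carbon) which puts hydrogen in place of methyl on a saturated chain carbon, five bonds along the chain from an aromatic carbon. Among the compounds with values here, the one measured step that bears on this swaps the whole hexyl group for phenyl and amounts to a 3.7-fold lower number from compound 2 to compound 3 (0.57 log units; beyond the scatter) even so. Within the data shown here, with that modest step as the only guide, no shift beyond the scatter is expected for this much smaller edit in this assay in either direction. The step expected here is a 1.1-fold lower number from compound 2 to compound 4 (0.04 log units; within the scatter) and it is estimated to stay small. Compound 4 is estimated at 8000 nM with an expected range of 4000 nM to 16000 nM in this read-out.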

Compound 4, half-maximal inhibitory concentration: 8250 nM
For compound 4 the middle estimate is 1.0-fold (0.01 log units) below the measured one, within the range that was stated.
By their numbers in this assay, from the lowest: compounds 3, 1, 4 and 2 (each within the scatter of the next, the first and the last beyond it).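

Removing the end methyl of the hexyl group gives a 1.1-fold lower number from compound 2 to compound 4 (0.02 log units; within the scatter) in this assay, so at this chain end the single carbon counts for little in this read-out. Pentyl and phenyl remain clearly apart, with a 3.5-fold higher number from compound 3 to compound 4 (0.55 log units; beyond the scatter) on that swap, which shows that the gap first seen with hexyl survives when the chain is one carbon shorter. Nothing available explains either result.

As far as these compounds go, whether the number stays just as flat with butyl, propyl or ethyl on the same aromatic carbon remains open, as does the effect of a longer chain such as heptyl. Also open, from the compounds shown here alone, is what an amine or a carboxylic acid at the end of the chain would do.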